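Moving a Bromine Around the Ring of a Thioether Amine

A few compounds are considered here, and "the series" means these few. Any claim that something is new, unique, unknown or untested is made for them only; others in the source may bear on it.

Compound 2 `CC(N)CSc1ccccc1` is the unsubstituted member of this small series. Within the data shown here, in an assay on isolated protein for inhibition of Amine oxidase [flavin-containing] A (Homo sapiens), read by fluorescence and spectrophotometry (on this read-out higher numbers stand for weaker inhibition and lower numbers for stronger inhibition), compound 2 gives 4720 nM, the highest of the two numbers recorded so far; its only neighbour is compound 1 `CC(N)CSc1ccccc1Br`, which in this assay gives 724 nM. Among the measured compounds shown here, the single step measured between them runs a 6.5-fold higher number from compound 1 to compound 2 (0.81 log units; beyond the scatter), so taking the bromo off that aromatic carbon weakened inhibition by a modest but clear margin.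

Compound 3 `CC(N)CSc1cccc(Br)c1` goes the other way: bromo in place of hydrogen on an aromatic carbon, the new bromo sitting on an aromatic carbon of a six-membered aromatic ring of carbon only, meta to a group of 5 heavy atoms. The step from compound 1 to compound 2 is the only one that bears on this change, and it shows that a bromo on the ring can lower the number in this assay substantially. Whether a bromo on a different aromatic carbon does the same cannot be read from two compounds. A smaller gain is therefore expected for compound 3, with a step of a 3.1-fold lower number from compound 2 to compound 3 (0.50 log units; beyond the scatter). The estimate for compound 3 in this assay is 1500 nM, within a range from 500 nM to 5000 nM.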

Compound 3, half-maximal inhibitory concentration: 7820 nM
Compound 3: the middle estimate sits 5.2-fold (0.72 log units) below what was measured; measured number above the stated range.
By their numbers in this assay, from the lowest: compound 1; then compounds 2 and 3 (each within the scatter of the next).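

In this assay, the step for bromo in place of hydrogen on an aromatic carbon, meta to a group of 5 heavy atoms, reads a 1.7-fold higher number from compound 2 to compound 3 (0.22 log units; within the scatter) and so leaves compound 3 indistinguishable from the unsubstituted compound 2. The earlier step, a 6.5-fold higher number from compound 1 to compound 2 (0.81 log units; beyond the scatter), had shown only that the bromo of compound 1 matters in this assay, whereas compound 3 shows that merely having a bromo on the ring is not enough, and that where it sits on the ring counts. Nothing available explains why the two placements of the bromo read so differently.

The compounds shown leave open whether a bromo on any other aromatic carbon of the ring would behave like that of compound 1 or like that of compound 3, and whether a different group on this same carbon, such as chloro, methoxy or a nitrile, would read any differently from hydrogen. They also leave open how either bromo placement would fare with a longer chain between the sulfur and the amine, or with a methyl group on that amine.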